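A few compounds are considered here, and "the series" means these few. Any claim that something is new, unique, unknown or untested is made for them only; others in the source may bear on it.

Among the compounds with values here, compound 3 `Cc1ccc(-c2nnc(SCCOc3ccc(/C=C4\SC(=O)NC4=O)cc3)[nH]2)cc1` is one of three compounds measured in a functional assay on the whole organism (plasma, strain Wistar) with Rattus norvegicus as the target, with a stated time of 15 days, at a dose of 30 mg/kg by the oral route; a higher number here means a stronger effect of the compound at the dose given, a lower number a weaker effect. Compound 1 `Cc1nc(COc2ccc(/C=C3\SC(=O)NC3=O)cc2)cs1` gives 14.7%, compound 2 `O=C1NC(=O)/C(=C/c2ccc(OCc3csc(-c4ccccc4)n3)cc2)S1` gives 22.6%, and compound 3 gives 22.6%. Compound 3 thus stands level with compound 2 at the digits printed, the two together forming the highest numbers of the three, while compound 1 sits lower, though the gap to compound 3 is within the scatter.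

Compound 4 `O=C1NC(=O)/C(=C/c2ccc(OCCSc3nnc(-c4ccc(Cl)cc4)[nH]3)cc2)S1` differs from compound 3 in one place: chloro in place of methyl on an aromatic carbon. Within the data shown here, the only measured step, a number 7.9 percentage points higher from compound 1 to compound 2 (within the scatter), also swaps a group on an aromatic carbon, and it stayed within the scatter. Among the measured compounds shown here, no measured step exchanges methyl for chloro, so no guide exists for that exchange itself. On this basis the step is expected to be small: compound 4 is estimated to lie near compound 3, with an expected step of a number 0.4 percentage points higher from compound 3 to compound 4 (within the scatter). Compound 4 is therefore expected to give 23% in this assay, within a range from 12% to 34%.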

Compound 4, a percentage reported as activity, at one dose (the size of the read-out at that dose, not a potency): 23.7%
Estimate against measurement, compound 4: 0.7 percentage points below, within the range that was stated.
By their numbers in this assay, from the lowest: compounds 1, 2, 3 and 4 (each within the scatter of the next).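

In this assay, within the data shown here, going from 4-methylphenyl to 4-chlorophenyl gives a number 1.1 percentage points higher from compound 3 to compound 4 (within the scatter), the first direct reading of this exchange on the ring that carries the group para to a large group. One heavy atom replaces another here, neither adding a hydrogen-bond donor or acceptor, and the read-out does not separate methyl from chloro at this position. Nothing measured here bears on the reason for this result.

The compounds shown leave open whether a group of another kind at this position, such as an amine or a carboxylic acid, would give a step beyond the scatter. Each compound is also read at one dose only, which leaves open how methyl and chloro would compare at other doses.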